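The compounds below may be only part of what the source reports. "The series", "measured", "known", "first", "only" and "open" are said of these compounds alone.

Measured so far:
Compound 1 `CCCCC#Cc1nc(N)c2ncn([C@@H]3OC[C@@H](O)[C@H]3O)c2n1` gives 138 nM in an assay on CHO cells for displacement of a labelled ligand from adenosine receptor A3 (Homo sapiens), with a stated time of 60 min; on this read-out higher numbers stand for weaker inhibition and lower numbers for stronger inhibition.
Compound 2 `CCCCC#Cc1nc(NCc2cccc(F)c2)c2ncn([C@@H]3OC[C@@H](O)[C@H]3O)c2n1` gives 570 nM in this assay.

In this assay, within the data shown here, compound 2 holds the higher of the two numbers; the one measured step is a 4.1-fold higher number from compound 1 to compound 2 (0.62 log units; beyond the scatter). Compound 3 `CCCCC#Cc1nc(NCc2cccc(I)c2)c2ncn([C@@H]3OC[C@@H](O)[C@H]3O)c2n1` differs from compound 2 by iodo in place of fluoro on an aromatic carbon. Among the measured compounds shown here, that step concerned adding the whole benzyl group, so it does not bear directly on an exchange of one halogen for another, and no measured step does. Compound 3 is therefore expected close to compound 2, with a 1.6-fold lower number from compound 2 to compound 3 (0.21 log units; within the scatter) not beyond the scatter, and its estimate in this assay is 350 nM within a range of 90 nM to 1400 nM.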

Compound 3, inhibition constant: 220 nM
For compound 3 the middle estimate is 1.6-fold (0.20 log units) above the measured one, within the range that was stated.
By their numbers in this assay, from the lowest: compounds 1 and 3 (each within the scatter of the next); then compound 2.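

In this assay, the halogen on the benzyl group proves to count: iodo in place of fluoro gives a 2.6-fold lower number from compound 2 to compound 3 (0.41 log units; beyond the scatter) at this ring position. With 3-iodobenzyl on the nitrogen, the comparison with the unsubstituted amino compound reads a 1.6-fold higher number from compound 1 to compound 3 (0.20 log units; within the scatter), so this nitrogen can carry a benzyl group without a step beyond the scatter, which the 3-fluorobenzyl group did not show. No measured evidence here accounts for the difference between the two halogens.

On these data alone, how chloro, bromo or a methoxy group would read at the same place remains open. So does the effect of iodo elsewhere on the ring.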